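A few compounds are considered here, and "the series" means these few. Any claim that something is new, unique, unknown or untested is made for them only; others in the source may bear on it.

Compound 1, `CNC(=O)Nc1ccccc1-c1ccc(CN2C(=O)[C@H](NC(=O)CC(C)(C)N)CCc3ccccc32)cc1`, is examined in a functional assay (Pituitary gland cell) with Rattus norvegicus as the target (a lower number here means that less compound is needed, a higher number that more compound is needed for the effect), where compound 1 gives 50 nM. Among the two numbers at hand this is the lowest: the nearest, compound 2, `CC(C)(N)C(=O)N[C@@H]1CCc2ccccc2N(Cc2ccc(-c3ccccc3CNC(=O)NCc3ccccc3)cc2)C1=O`, gives 390 nM in this assay, a gap beyond the usual scatter. Compound 3, `CC(=O)NCc1ccccc1-c1ccc(CN2C(=O)[C@H](NC(=O)CC(C)(C)N)CCc3ccccc32)cc1`, has not yet been measured in this assay. It differs from compound 1 in one place: acetamidomethyl in place of (methylcarbamoyl)amino on an aromatic carbon. Going by the values given here, no measured pair shows this exact change, so its effect can only be anticipated. A modest rise, possibly beyond the scatter, is expected from compound 1 to compound 3 a 3.0-fold higher number from compound 1 to compound 3 (0.48 log units; beyond the scatter). Compound 3 is therefore estimated at 150 nM, within 50 nM to 500 nM.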

Compound 3, concentration for half-maximal effect: 200 nM
Compound 3: the middle estimate sits 1.3-fold (0.12 log units) below what was measured, and the stated range covers the measured number.
By their numbers in this assay, from the lowest: compound 1; then compounds 3 and 2 (each within the scatter of the next).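

Going by these compounds alone, exchanging (methylcarbamoyl)amino for acetamidomethyl on this aromatic carbon, ortho to a large group, gives a 4.0-fold higher number from compound 1 to compound 3 (0.60 log units; beyond the scatter) in this assay, the only step here between compounds that differ in one place. The position is therefore sensitive to this change, although both groups hold 5 heavy atoms and the entering group has 1 hydrogen-bond donor against 2. Nothing at hand accounts for the size of this step. Open, from the compounds shown here alone, is how an acetamido group, a plain amine or a carboxylic acid on the same aromatic carbon would read in this assay.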